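The compounds below may be only part of what the source reports. "The series", "measured", "known", "first", "only" and "open" are said of these compounds alone.

Measured so far:
compound 1 `COC(CCn1cnc2c(NCc3ccc(C(=O)Nc4ccccc4N)cc3)nc(Cl)nc21)OC` — 8.52%
compound 2 `Nc1ccccc1NC(=O)c1ccc(Cn2cnc3c(NCc4ccccc4)nc(Cl)nc32)cc1` — 7.55%

In a functional assay on HepG2 cells (Homo sapiens) for antiproliferative activity, read by CCK-8 assay, with a stated time of 72 h, tested at 2 uM (a lower number here means a weaker effect, a higher number a stronger effect of the compound at the concentration tested), compound 1 gives 8.52% and compound 2 gives 7.55%; the two values lie within the scatter of each other, so neither stands apart. Both compounds are weak at the concentration tested.

Compound 3 `CN1CCN(c2nc(Cl)nc3c2ncn3Cc2ccc(C(=O)Nc3ccccc3N)cc2)CC1` is not yet measured. It differs from compound 2 by 4-methylpiperazin-1-yl in place of benzylamino on an aromatic carbon. Among the measured compounds shown here, no measured pair shows what this exchange does in this assay. For the measured compounds named here, with both measured compounds weak and no step to lean on, compound 3 is expected to stay near compound 2, a step of a number 2.5 percentage points higher from compound 2 to compound 3 (within the scatter) not beyond the scatter. The estimate for compound 3 is 10%, ranging from 0% to 28%.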

Compound 3, a percentage reported as inhibition, at one concentration (the size of the read-out at that concentration, not a potency): 60.4%
Compound 3: middle estimate off by 50.4 percentage points, on the low side; measured number outside the range, above it.
By their numbers in this assay, from the lowest: compounds 2 and 1 (each within the scatter of the next); then compound 3.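

In this assay, 4-methylpiperazin-1-yl in place of benzylamino on an aromatic carbon gives a number 52.9 percentage points higher from compound 2 to compound 3 (beyond the scatter). The group at this position therefore has a large bearing on the read-out, whereas compound 1 and compound 2, which both carry benzylamino here, lie within the scatter of each other. Nothing available explains the size of this step.

Still open, from the compounds shown here alone, is whether the gain needs the whole 4-methylpiperazin-1-yl group, or whether piperazine without its methyl, morpholine or piperidine at this position would match it. Also open, going by these compounds, is how the chloro group contributes, for instance against an amine at that place.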